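The source may report more compounds than this note shows. Statements on the series, on what has been measured and on what is new or still open speak of the compounds shown alone.

Compound 1 `O=C1C(=O)N(Cc2cn(CC(=O)N3CCN(c4cc5c(cc4F)c(=O)c(C(=O)O)cn5C4CC4)CC3)nn2)c2ccc(F)cc21`: 32 ug/mL
Compound 2 `CO/N=C1/C(=O)N(Cc2cn(CC(=O)N3CCN(c4cc5c(cc4F)c(=O)c(C(=O)O)cn5C4CC4)CC3)nn2)c2ccccc21`: 128 ug/mL
Compound 3 `O=C1C(=O)N(Cc2cn(CC(=O)N3CCN(c4cc5c(cc4F)c(=O)c(C(=O)O)cn5C4CC4)CC3)nn2)c2c(F)cccc21`: 8 ug/mL

These three compounds share one core and were tested in an ADME assay on Vero cells (Chlorocebus sabaeus) for cytotoxicity; a lower number here means that less compound is tolerated, a higher number that more compound is tolerated. Among them compound 2 stands highest; compound 1 sits next, and compound 3 gives the lowest number of the three, both gaps being beyond the scatter.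

Compound 4 `CO/N=C1/C(=O)N(Cc2cn(CC(=O)N3CCN(c4cc5c(cc4F)c(=O)c(C(=O)O)cn5C4CC4)CC3)nn2)c2c(F)cccc21` differs from compound 2 by fluoro in place of hydrogen on an aromatic carbon, the ring in question being a six-membered aromatic ring of carbon only within a fused system of two rings. For the measured compounds named here, one measured step bears on this change: a 4.0-fold lower number from compound 1 to compound 3 (0.60 log units; beyond the scatter). In that step the fluorine of compound 3 sits at the same place as the fluorine that enters compound 4, and the number fell beyond the scatter. The match is not exact, as compound 1 already carries a fluorine on that ring while compound 2 carries none, so some caution is warranted. Still, a lower number is expected for compound 4, with the expected step being a 2.7-fold lower number from compound 2 to compound 4 (0.43 log units; beyond the scatter). Compound 4 is therefore estimated at 48 ug/mL, within a range from 16 ug/mL to 128 ug/mL.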

Compound 4, half-maximal cytotoxic concentration: 32 ug/mL
The estimate for compound 4 lay 1.5-fold (0.18 log units) above the measured number; measured number inside the range.
By their numbers in this assay, from the lowest: compound 3; then compounds 1 and 4 (each within the scatter of the next); then compound 2.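

In this assay, for the compounds shown here, putting fluoro in place of hydrogen on this aromatic carbon gives a 4.0-fold lower number from compound 2 to compound 4 (0.60 log units; beyond the scatter), and this is the first step here in which a fluorine enters with nothing else on that ring changing, so the change can be read on its own. The earlier step, a 4.0-fold lower number from compound 1 to compound 3 (0.60 log units; beyond the scatter), also ended with a fluorine at this place, but it started from a compound that already carried a fluorine elsewhere on that ring. The two steps are printed with the same size, so in both pairs, one with the carbonyl of compound 3 and one with the methoxyimino group of compound 4, a fluorine at this place goes with less compound being tolerated, though no measurement here explains why.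

The compounds shown leave open whether a chlorine, a methyl group or an amine on this same aromatic carbon would lower the number as fluoro does. From the compounds shown here alone, it also remains open whether fluoro on a different carbon of that ring would have the same effect in compounds carrying the methoxyimino group.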